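The source may hold more compounds than are shown below. What is called first, only, known or untested is meant among the compounds shown, and "the series" means these compounds.

Measured compounds and their values:
compound 1 `CC#CC(CC(=O)O)c1ccc(OCC2COc3ccc(Cl)cc3O2)cc1` — 100 nM
compound 2 `CC#C[C@@H](CC(=O)O)c1ccc(OC[C@H]2COc3ccc(Cl)cc3O2)cc1` — 50 nM
compound 3 `CC#C[C@@H](CC(=O)O)c1ccc(OC[C@@H]2COc3ccc(Cl)cc3O2)cc1` — 260 nM

All three were tested in a functional assay on HEK293 cells for agonist activity at Free fatty acid receptor 1 (Homo sapiens), read by fluorescence and calcium flux, with a stated time of 10 min; on this read-out higher numbers stand for an effect only at larger amounts of compound and lower numbers for an effect already at smaller amounts. Compound 2 gives the lowest number of the three, but its step to compound 1, a 2.0-fold lower number from compound 1 to compound 2 (0.30 log units; within the scatter), lies within the scatter, so the two cannot be ranked. The step of a 5.2-fold higher number from compound 2 to compound 3 (0.72 log units; beyond the scatter) is beyond the scatter; compounds 2 and 3 differ only in the configuration as drawn the fact that compounds 2 and 3 differ only in the configuration as drawn at the saturated ring carbon, and compound 1 is drawn without any configuration the fact that one of compounds 1 and 2 is drawn with a defined configuration and the other without, at the place where they differ (the fact that one of compounds 1 and 3 is drawn with a defined configuration and the other without, at the place where they differ).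

Compound 4 `CC#C[C@@H](CC(=O)O)c1ccc(OC[C@H]2COc3ccccc3O2)cc1` differs from compound 2 by hydrogen in place of chloro on an aromatic carbon. Among the compounds with values here, none of the measured steps bears directly on this change: all three concern configuration alone, with the same atoms and bonds throughout. The change removes a single heavy atom, and the expected step in this assay is therefore modest, most likely toward a higher number, comparable in size to the modest steps already seen rather than a large jump. Compound 4 is estimated at 150 nM, with a range from 50 nM to 500 nM. The step this estimate means, a 3.0-fold higher number from compound 2 to compound 4 (0.48 log units; beyond the scatter), is expected to be modest.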

Compound 4, half-maximal effective concentration: 90 nM
Compound 4: middle estimate off by 1.7-fold (0.22 log units), on the high side; low and high end bracket the measured number.
By their numbers in this assay, from the lowest: compounds 2, 4 and 1 (each within the scatter of the next); then compound 3.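

Within the data shown here, this is the first look at the chloro group itself, since every earlier step concerned configuration alone. In this assay, putting hydrogen in place of chloro on the aromatic carbon gives a 1.8-fold higher number from compound 2 to compound 4 (0.26 log units; within the scatter), so the two cannot be ranked and, in this pair, chloro is not needed for an effect at these concentrations, whereas the change in configuration at the saturated ring carbon gave a 5.2-fold higher number from compound 2 to compound 3 (0.72 log units; beyond the scatter) and could be read. The available facts concern configuration only, and none of them explains this result.

On these data alone, whether a larger or different group at the same place, such as methoxy or nitrile, would also leave the number within the scatter remains open. As far as these compounds go, it is equally open whether hydrogen in place of chloro would behave the same way with the opposite configuration at the saturated ring carbon.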